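Benzhydryl sulfoxide series: heteroaryl variation at the methylene carbon

The source may hold more compounds than are shown below. What is called first, only, known or untested is meant among the compounds shown, and "the series" means these compounds.

Measured so far in an assay on HEK293 cells for inhibition of sodium-dependent dopamine transporter (Homo sapiens), read by scintillation counting, with stated times of 5 min and 1 min; on this read-out higher numbers stand for weaker inhibition and lower numbers for stronger inhibition:
- compound 1 `Cc1nc(O)cc(C[S+]([O-])C(c2ccccc2)c2ccccc2)n1` gives 3100 nM
- compound 2 `[O-][S+](Cc1cc(Br)cs1)C(c1ccccc1)c1ccccc1` gives 13700 nM
- compound 3 `[O-][S+](Cc1cc(C2CC2)on1)C(c1ccccc1)c1ccccc1` gives 38600 nM

Compound 2 sits second highest of the three numbers. Its nearest neighbour is compound 3, reached by a 2.8-fold higher number from compound 2 to compound 3 (0.45 log units; beyond the scatter); its furthest is compound 1, from which compound 2 is reached by a 4.4-fold higher number from compound 1 to compound 2 (0.65 log units; beyond the scatter). The full span of the series is a 12-fold higher number from compound 1 to compound 3 (1.10 log units; beyond the scatter).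

The next compound, compound 4 `[O-][S+](Cc1ccncc1)C(c1ccccc1)c1ccccc1`, has not yet been measured. It differs from compound 2 as follows: pyridin-4-yl in place of 4-bromothiophen-2-yl on a saturated chain carbon bound to a sulfur.

Going by the values given here, two measured steps bear on this change, since both swap the group on the saturated chain carbon bound to a sulfur: the step from compound 1 to compound 2 and the step from compound 2 to compound 3. Both were modest, and the six-membered ring with one nitrogen and one hydrogen-bond acceptor that enters in compound 4 shares more with the 6-hydroxy-2-methylpyrimidin-4-yl of compound 1 than with the 5-cyclopropyl-1,2-oxazol-3-yl of compound 3. A small step toward a lower number in this assay is therefore expected for compound 4, about the size of the scatter, though the missing hydroxy group of compound 1 leaves this uncertain. The expected value for compound 4 is 7000 nM, within 2500 nM to 20000 nM, which means an expected step of a 2.0-fold lower number from compound 2 to compound 4 (0.29 log units; within the scatter).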

Compound 4, half-maximal inhibitory concentration: 63500 nM
Estimate against measurement, compound 4: 9.1-fold (0.96 log units) below; the measured number lies above the stated range.
By their numbers in this assay, from the lowest: compound 1; then compound 2; then compounds 3 and 4 (each within the scatter of the next).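

In this assay, a six-membered aromatic ring on the saturated chain carbon bound to a sulfur does not by itself keep the number low: a 20-fold higher number from compound 1 to compound 4 (1.31 log units; beyond the scatter), the largest step in the series, separates the two six-membered rings, so the low number of compound 1 goes with something in its 6-hydroxy-2-methylpyrimidin-4-yl that pyridin-4-yl lacks. Counts do not track the read-out at this position either, since pyridin-4-yl and 4-bromothiophen-2-yl match in heavy atoms, hydrogen-bond donors and hydrogen-bond acceptors, yet the change gives a 4.6-fold higher number from compound 2 to compound 4 (0.67 log units; beyond the scatter). Ring size does not sort the series, as a 1.6-fold higher number from compound 3 to compound 4 (0.22 log units; within the scatter) leaves compound 4 with its six-membered ring indistinguishable from compound 3 with its five-membered ring, while compound 2, also five-membered, stands apart from both.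

No measurement at hand accounts for any of these steps. Open, from the compounds shown here alone, is whether the hydroxy group or the methyl group of compound 1 carries its lower number, which a pyridin-4-yl bearing a hydroxy group or a methyl group, or a plain phenyl at the same place, could begin to separate.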